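Changing the amine on the thiocarbonyl carbon

The compounds below may be only part of what the source reports. "The series", "measured", "known", "first", "only" and "open" are said of these compounds alone.

Of the compounds shown here, two built on one shared core have been tested in a functional assay on A-375 cells (Homo sapiens) for antiproliferative activity, read by CCK-8 assay, with a stated time of 72 h, tested at 2 uM; on this read-out lower numbers stand for a weaker effect and higher numbers for a stronger effect at the one concentration tested. Compound 1 `Nc1ccccc1NC(=O)c1ccc(CSC(=S)N2CCc3cc(Cl)ccc32)cc1` gives 31.9%. Going by the values given here, compound 2 `CCN(Cc1ccncc1)C(=S)SCc1ccc(C(=O)Nc2ccccc2N)cc1` gives 67.2%, which is the higher of the two numbers, and compound 1 is its only neighbour, standing well below it. Among the compounds with values here, the one measured step, a number 35.3 percentage points higher from compound 1 to compound 2 (beyond the scatter), shows that the group attached to the thiocarbonyl carbon can move the read-out a long way.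

Compound 3 `CC1CCN(C(=S)SCc2ccc(C(=O)Nc3ccccc3N)cc2)CC1` differs from compound 2 at that same place: 4-methylpiperidin-1-yl in place of ethyl((pyridin-4-yl)methyl)amino on a thiocarbonyl carbon. Within the data shown here, the only step that bears on this change is the one from compound 1 to compound 2, which was large and upward when a ring-bearing amine gave way to the ethyl((pyridin-4-yl)methyl)amino group. Compound 3 again carries a ring amine, though a different one from that in compound 1, so the read-out is expected to move partway back toward the number of compound 1 rather than all the way. The estimate for compound 3 is 45%, within 20% to 70%, meaning an expected step of a number 22.2 percentage points lower from compound 2 to compound 3 (beyond the scatter).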

Compound 3, a percentage reported as inhibition, at one concentration (the size of the read-out at that concentration, not a potency): 32.7%
Beside the measured number, compound 3's estimate is 12.3 percentage points above it; low and high end bracket the measured number.
By their numbers in this assay, from the lowest: compounds 1 and 3 (each within the scatter of the next); then compound 2.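

Swapping ethyl((pyridin-4-yl)methyl)amino for 4-methylpiperidin-1-yl on the thiocarbonyl carbon changes the outcome sharply in this assay, with the read-out moving by a number 34.5 percentage points lower from compound 2 to compound 3 (beyond the scatter). The comparison with the other ring amine gives a number 0.8 percentage points higher from compound 1 to compound 3 (within the scatter), so 5-chloro-2,3-dihydro-1H-indol-1-yl and 4-methylpiperidin-1-yl cannot be told apart here, even though they are quite different groups. Among these three compounds, the high number therefore belongs to the ethyl((pyridin-4-yl)methyl)amino group alone, and no measurement shown here explains why it stands apart.

That group differs from 4-methylpiperidin-1-yl in more than one way, since it carries an aromatic ring with a hetero atom and its amine nitrogen is not part of a ring, so the compounds shown leave open which of these features goes with the higher number. An ethyl(benzyl)amino group, with a plain benzene ring in place of the pyridine ring, or a 4-(pyridin-4-yl)piperidin-1-yl group, which holds the pyridine ring on a cyclic amine, would help to separate the two features.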